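From 4-methylphenyl to 6-chloropyridin-3-yl in compound 1

The compounds below may be only part of what the source reports. "The series", "measured", "known", "first", "only" and "open" are said of these compounds alone.

Values measured in a functional assay on HeLa cells (Homo sapiens) for inhibition, with a stated time of 72 h; on this read-out higher numbers stand for an effect only at larger amounts of compound and lower numbers for an effect already at smaller amounts
- compound 1 `COc1cc(CNCc2ccncc2)ccc1OCc1ccc(C)cc1` gives 5000 nM
- compound 2 `COc1cc(CNc2nc[nH]n2)ccc1OCc1ccc(Cl)nc1` gives 69000 nM

Compound 1 holds the lower number of the two at 5000 nM and compound 2 stands at 69000 nM with a gap beyond the scatter. Compound 3 `COc1cc(CNCc2ccncc2)ccc1OCc1ccc(Cl)nc1` keeps the core of compound 1 and differs from it in one place 6-chloropyridin-3-yl in place of 4-methylphenyl on a saturated chain carbon bound to an oxygen on an aromatic ring with 6-chloropyridin-3-yl in place of 4-methylphenyl on a saturated chain carbon bound to an oxygen on an aromatic ring. Among the compounds with values here, no measured pair shows this change alone. Compound 2 carries the same 6-chloropyridin-3-yl group, but it also differs from compound 1 elsewhere, so the number of compound 2 at 69000 nM cannot be assigned to that group. In this assay a modest step toward a higher number is therefore expected, and it may stay within the scatter. The expected step on this estimate runs a 1.8-fold higher number from compound 1 to compound 3 (0.26 log units; within the scatter) and no further. Compound 3 is estimated at 9000 nM with an expected range from 2500 nM to 30000 nM in this assay once measured.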

Compound 3, half-maximal effective concentration: 400 nM
Beside the measured number, compound 3's estimate is 23-fold (1.35 log units) above it; the whole stated range lies above it.
By their numbers in this assay, from the lowest: compound 3; then compound 1; then compound 2.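

In this assay, 6-chloropyridin-3-yl in place of 4-methylphenyl on a saturated chain carbon bound to an oxygen on an aromatic ring gives a 13-fold lower number from compound 1 to compound 3 (1.10 log units; beyond the scatter), so the number responds strongly to the group at this position when the rest of compound 1 is held constant. With 6-chloropyridin-3-yl present in both compounds, (pyridin-4-yl)methyl in place of 1H-1,2,4-triazol-3-yl on an amine nitrogen gives a 170-fold lower number from compound 2 to compound 3 (2.24 log units; beyond the scatter), so the high number of compound 2 does not follow from 6-chloropyridin-3-yl alone, a separation that compounds 1 and 2 could not make. Nothing available explains either step.

From the compounds shown here alone, the step from compound 1 to compound 3 exchanges the ring nitrogen, the chlorine and the methyl together, so the share of each stays open; 4-chlorophenyl and 6-methylpyridin-3-yl at the same position would help to separate them. Also open, going by these compounds, is whether the same exchange would lower the number with 1H-1,2,4-triazol-3-yl on the amine nitrogen, or with another group there, such as benzyl.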